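The compounds below may be only part of what the source reports. "The series", "measured", "known", "first", "only" and "open" are said of these compounds alone.

In a functional assay (trachea) with Cavia porcellus as the target (on this read-out higher numbers stand for weaker inhibition and lower numbers for stronger inhibition), compound 1 `CCOC(=O)Cn1nc(-c2cccnc2)c2ccccc2c1=O` gives 43700 nM. Compound 2 `O=C(O)CCCn1nc(-c2cccnc2)c2ccccc2c1=O` reaches only a limit of the assay, > 100000 nM. Going by the values given here, the single measured step, an at least 2.2-fold higher number from compound 1 to compound 2 (0.35 log units; beyond the scatter), is at least modest and ends at the limit of > 100000 nM in this assay, at which 1 of the 2 values shown sits. Compound 3 `CC(C)NC(=O)CCCn1nc(-c2cccnc2)c2ccccc2c1=O` differs from compound 2 by isopropylamino in place of hydroxy on a carbonyl carbon, which turns carboxy into isopropylcarbamoyl. Compound 1 at 43700 nM also carries no carboxy, so a move to lower numbers in this assay is expected, though its size is poorly fixed by one step. The estimated step is an at least 3.3-fold lower number from compound 2 to compound 3 (0.52 log units; beyond the scatter). Compound 3 is estimated at 30000 nM, with an expected range of 6000 nM to 100000 nM.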

Compound 3, half-maximal inhibitory concentration: 64600 nM
For compound 3 the middle estimate is 2.2-fold (0.33 log units) below the measured one, within the range that was stated.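

In this assay, carboxy to isopropylcarbamoyl gives an at least 1.5-fold lower number from compound 2 to compound 3 (0.18 log units; that floor lies within the scatter). Compound 2 is a limit of the assay, so the true size of this step stays unfixed. The amide compound and the ester compound cannot be told apart, with a 1.5-fold higher number from compound 1 to compound 3 (0.17 log units; within the scatter), so this chain position has now held two different non-acid ends without separating them.

As far as these compounds go, whether a terminal amine or a longer chain would give lower numbers remains open. So does how a carboxylic acid on the shorter chain of compound 1 would read.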